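From chloro to trifluoromethyl on the aromatic ring

The source may report more compounds than this note shows. Statements on the series, on what has been measured and on what is new or still open speak of the compounds shown alone.

Measured so far in an ADME assay (liver) for metabolic stability, with Liver microsome (Homo sapiens) as the target, read by LC-MS, using microsomes, with a stated time of 30 min, tested at 4 uM (a higher number here means that more of the compound is left, a lower number that less of the compound is left), of this series:
- Compound 1 `COCCn1c(-c2ccccc2Cl)nc2c(N3CCN(C(C)=O)CC3)nc(C)nc21` gives 35% here
- Compound 2 `Cc1nc(N2CCN(C)CC2)c2nc(-c3ccccc3Cl)n(C3CC3)c2n1` gives 31% here
- Compound 3 `Cc1nc(N2CCN(C)CC2)c2nc(-c3cccc(Cl)c3)n(C3CCOCC3)c2n1` gives 25% here

Compound 3 stands at 25% in this assay and the three values lie within the usual scatter of one another. Compound 4 `Cc1nc(N2CCN(C)CC2)c2nc(-c3cccc(C(F)(F)F)c3)n(C3CCOCC3)c2n1` is compound 3 with trifluoromethyl in place of chloro on an aromatic carbon and still awaits measurement. No measured pair differs in one place, so the size of this step is not shown directly. In this assay no step beyond the scatter is expected. The estimated step is a number 3 percentage points higher from compound 3 to compound 4 (within the scatter) and it stays within the scatter, in a slightly upward direction. For compound 4 the expected value is 28% with an estimated range from 13% to 46% for now.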

Compound 4, percent of the compound remaining: 19%
Compound 4: the middle estimate sits 9 percentage points above what was measured, within the range that was stated.
By their numbers in this assay, from the lowest: compounds 4, 3, 2 and 1 (each within the scatter of the next, the first and the last beyond it).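

Among these compounds, the change from 3-chlorophenyl to 3-(trifluoromethyl)phenyl gives the first step that can be read at a single place: in this assay it is a number 6 percentage points lower from compound 3 to compound 4 (within the scatter) and so offers no basis for telling the two groups apart at this position. Going from one heavy atom to four on this aromatic carbon therefore leaves the read-out within what repeated measurements would show. No measured information at hand accounts for this result.

Going by these compounds, whether a nitrile, a methoxy group or a carboxylic acid on this aromatic carbon would give a step beyond the scatter stays open. So does whether the same exchange would read alike with the other groups on the shared core.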